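The compounds below may be only part of what the source reports. "The series", "measured", "known", "first", "only" and "open" are said of these compounds alone.

Measured so far in a functional assay on HeLa cells (Homo sapiens) for cytotoxicity, read by MTT assay, with a stated time of 72 h; on this read-out lower numbers stand for stronger inhibition and higher numbers for weaker inhibition:
- compound 1, `O=C1c2cccc([N+](=O)[O-])c2NC[C@@]12[C@H](c1ccc(Br)cc1)[C@@H](c1ccccc1)N[C@]21C(=O)Nc2ccc(Cl)cc21`, gives 21000 nM
- compound 2, `O=C1c2cccc([N+](=O)[O-])c2NC[C@@]12[C@H](c1ccc(F)cc1)[C@@H](c1ccccc1)N[C@]21C(=O)Nc2ccc(Cl)cc21`, gives 27000 nM

Within the data shown here, compound 2 stands at the higher of the two numbers, but the only step that connects it to another compound, a 1.3-fold higher number from compound 1 to compound 2 (0.11 log units; within the scatter), lies within the scatter, so the two numbers cannot be placed in order.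

Compound 3, `COc1ccc([C@@H]2[C@@H](c3ccccc3)N[C@]3(C(=O)Nc4ccc(Cl)cc43)[C@]23CNc2c(cccc2[N+](=O)[O-])C3=O)cc1`, has not yet been tested. It differs from compound 2 by methoxy in place of fluoro on an aromatic carbon. Among the measured compounds shown here, the one step known on this position, a 1.3-fold higher number from compound 1 to compound 2 (0.11 log units; within the scatter), exchanged one halogen for another without a change beyond the scatter. For the measured compounds named here, no step exchanges a halogen for a methoxy group here, so the expectation rests on that single step alone.

Compound 3 is therefore expected to give a number near that of compound 2 in this assay, an estimated 25000 nM, with a range from 9000 nM to 70000 nM, which means an expected step of a 1.1-fold lower number from compound 2 to compound 3 (0.03 log units; within the scatter).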

Compound 3, half-maximal inhibitory concentration: 16000 nM
The estimate for compound 3 lay 1.6-fold (0.19 log units) above the measured number, and the stated range covers the measured number.
By their numbers in this assay, from the lowest: compounds 3, 1 and 2 (each within the scatter of the next).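

In this assay methoxy in place of fluoro gives a 1.7-fold lower number from compound 2 to compound 3 (0.23 log units; within the scatter) and methoxy in place of bromo gives a 1.3-fold lower number from compound 1 to compound 3 (0.12 log units; within the scatter) and so neither exchange moves the number beyond the scatter. Until now this place, para to a large group on the six-membered aromatic ring, had only exchanged one halogen for another; it now also holds a group that is not a halogen and brings one hydrogen-bond acceptor by count, and the three numbers still cannot be placed in order. Nothing available bears on what lies behind these numbers.

On these data alone, whether any group at this place can move the number beyond the scatter remains open. An amine or a carboxylic acid there, in place of methoxy, would be the next exchange to read against these three compounds.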